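A few compounds are considered here, and "the series" means these few. Any claim that something is new, unique, unknown or untested is made for them only; others in the source may bear on it.

Series notes. Compound 1 `COc1cc2ncnc(NCc3cccc(NC(=O)Nc4cccc(C)c4)c3)c2cc1OC` and compound 2 `COc1cc2ncnc(NCc3cccc(NC(=O)Nc4ccccc4Cl)c3)c2cc1OC` share one core and differ only in the aryl group on the urea nitrogen. In a functional assay on A549 cells (Homo sapiens) for antiproliferative activity, read by MTT assay (a higher number here means a weaker inhibitor, a lower number a stronger inhibitor), compound 1 gives 27100 nM and compound 2 gives 15200 nM. The one step measured so far, a 1.8-fold lower number from compound 1 to compound 2 (0.25 log units; within the scatter), is within the scatter, so the two compounds stand level and compound 2 holds no clear edge over compound 1 on the numbers shown.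

Compound 3 `COc1cc2ncnc(NCc3cccc(NC(=O)Nc4ccc(Cl)cc4)c3)c2cc1OC` carries the change (4-chlorophenyl in place of 2-chlorophenyl on an amide-type nitrogen). Among the measured compounds shown here, no measured step moves the chlorine around the ring; the only comparison that touches this aryl group, a 1.8-fold lower number from compound 1 to compound 2 (0.25 log units; within the scatter), exchanged one substituted phenyl for another without a change beyond the scatter. On that basis the expectation for compound 3 is a step of about a 1.0-fold lower number from compound 2 to compound 3 (0.01 log units; within the scatter), that is, no movement beyond the scatter in either direction. Compound 3 is therefore estimated at 15000 nM in this assay, with a range from 6000 nM to 40000 nM.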

Compound 3, half-maximal inhibitory concentration: 30400 nM
Compound 3: middle estimate off by 2.0-fold (0.31 log units), on the low side; low and high end bracket the measured number.
By their numbers in this assay, from the lowest: compounds 2, 1 and 3 (each within the scatter of the next).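

Moving the chlorine, from 2-chlorophenyl to 4-chlorophenyl on the amide-type nitrogen, is the first change in the series that keeps the same atoms and only joins them differently, and it gives a 2.0-fold higher number from compound 2 to compound 3 (0.30 log units; within the scatter). In this assay, the position of the chlorine on this phenyl ring therefore has no effect that can be told from the scatter, although this step is larger than the other two steps in the series. The exchange of 3-methylphenyl for 4-chlorophenyl gives a 1.1-fold higher number from compound 1 to compound 3 (0.05 log units; within the scatter), so all three aryl groups now stand level in this assay, and nothing on hand bears on the reason for the small differences among them.

Still open, on these data alone, is whether any group on this nitrogen can move the number beyond the scatter, for example a phenyl ring carrying an amine or a carboxylic acid, or a longer alkyl chain in place of the aryl ring. Equally open, as far as these compounds go, is whether the flat response holds when the shared core changes, for instance with longer alkoxy chains in place of the two methoxy groups.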